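This account rests on a few compounds, and the source may have more. Where it says the series, first, only, none or still open, it means among the compounds named here.

Measured in a functional assay on MDCK cells (Canis lupus familiaris) for inhibition; a higher number here means that more compound is tolerated, a lower number that less compound is tolerated:
- Compound 1 `Cn1c(CC2(C)CO2)cc(=O)n(C)c1=O`: 4000 nM
- Compound 2 `C[C@@H]1O[C@@]1(C)Cc1cc(=O)n(C)c(=O)n1C`: 89000 nM

Of these two compounds, compound 2 has the higher number, so more of it is tolerated. Compound 3 `Cn1c(C[C@@H]2CCCO2)cc(=O)n(C)c1=O` has not yet been measured. It carries oxolan-2-yl in place of 2,3-dimethyloxiran-2-yl on a saturated chain carbon bound to an aromatic carbon.

Among the compounds with values here, only one measured step bears on this change, and it does so indirectly. That step is a 22-fold higher number from compound 1 to compound 2 (1.35 log units; beyond the scatter), which is large. It shows that this assay can respond strongly to a change at this place, but both of its compounds keep the three-membered ring, which compound 3 lacks. Its size and direction therefore cannot simply be carried over, and the range has to stay wide. Only a modest step, within the scatter and leaning upward, is expected. The expected step is a 1.5-fold higher number from compound 2 to compound 3 (0.16 log units; within the scatter). For compound 3 the estimated value is 130000 nM, and the expected range runs from 40000 nM to 400000 nM.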

Compound 3, half-maximal cytotoxic concentration: 1220000 nM
Estimate against measurement, compound 3: 9.4-fold (0.97 log units) below; the measured number lies above the stated range.
By their numbers in this assay, from the lowest: compound 1; then compound 2; then compound 3.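

In this assay, exchanging the three-membered ring for the five-membered ring on the saturated chain carbon gives a 14-fold higher number from compound 2 to compound 3 (1.14 log units; beyond the scatter) even though the two groups hold the same atoms, so the earlier picture of a strong response at this place now extends beyond changes that keep the three-membered ring. Measured against the 2-methyloxiran-2-yl group, oxolan-2-yl gives a 310-fold higher number from compound 1 to compound 3 (2.48 log units; beyond the scatter) and thus places compound 3 clearly above both compounds that carry a three-membered ring, with no listed compound going against that order. Nothing available accounts for the size of these steps.

The compounds shown leave open whether the rise tracks ring size as such or belongs to oxolan-2-yl in particular, a question that oxetan-2-yl, oxan-2-yl or cyclopentyl on the same saturated chain carbon would bear on. They also leave open what the single defined stereocentre of oxolan-2-yl contributes, and whether the opposite arrangement at that carbon would give a similar number in this assay.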